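Aryl swap on the thioether of compound 2

A few compounds are considered here, and "the series" means these few. Any claim that something is new, unique, unknown or untested is made for them only; others in the source may bear on it.

Within the data shown here, compound 2 `OC[C@H]1O[C@@H](n2cnc3c(CSc4ccccc4F)ncnc32)[C@H](O)[C@@H]1O` gives 355 nM in an assay on isolated protein for binding affinity to Equilibrative nucleoside transporter 1 (Homo sapiens) (on this read-out higher numbers stand for weaker inhibition and lower numbers for stronger inhibition), the lowest of the two numbers so far; compound 1 `Cc1cccc(CSc2ncnc3c2ncn3[C@@H]2O[C@H](CO)[C@@H](O)[C@H]2O)c1` gives 12000 nM, and the step of a 34-fold lower number from compound 1 to compound 2 (1.53 log units; beyond the scatter) is large. Compound 3 `OC[C@H]1O[C@@H](n2cnc3c(CSc4cccc(I)c4)ncnc32)[C@H](O)[C@@H]1O` carries 3-iodophenyl in place of 2-fluorophenyl on a sulfur. Among the measured compounds shown here, no measured step swaps one aryl group for another on the sulfur; the single step known also alters the link from sulfur to the ring, so it offers no direct guide. The step of a 1.1-fold higher number from compound 2 to compound 3 (0.05 log units; within the scatter) is therefore expected to stay small, within the scatter. For compound 3 the estimate is 400 nM, ranging from 100 nM to 1600 nM.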

Compound 3, half-maximal inhibitory concentration: 245 nM
For compound 3 the middle estimate is 1.6-fold (0.21 log units) above the measured one; low and high end bracket the measured number.
By their numbers in this assay, from the lowest: compounds 3 and 2 (each within the scatter of the next); then compound 1.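

Among these compounds, the swap of 3-iodophenyl for 2-fluorophenyl on the sulfur is the first change here confined to the aryl group, and in this assay it gives a 1.4-fold lower number from compound 2 to compound 3 (0.16 log units; within the scatter), so these two aryl groups are not told apart. The large gap to the 3-methylbenzyl thioether persists with a second aryl group, at a 49-fold lower number from compound 1 to compound 3 (1.69 log units; beyond the scatter). No evidence on the cause of either step is at hand.

That large step alters both the link from sulfur to the ring and the aryl group. The data do not separate these two changes. Also open, on these data alone, is the effect in this assay of an amine or a carboxylic acid on the aryl group.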